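This account rests on a few compounds, and the source may have more. Where it says the series, first, only, none or still open, it means among the compounds named here.

In a functional assay on SF-539 cells (Homo sapiens) for inhibition, read by sulforhodamine B assay, with a stated time of 48 h, tested at 10 uM (on this read-out higher numbers stand for more inhibition at the one concentration tested (going by the name of the read-out) and lower numbers for less inhibition), compound 1 `c1ccc(-c2cn3ccnc3c(-c3ccc4ncn(C5CCCCC5)c4c3)n2)cc1` gives 27.8% and compound 2 `O=Cc1ccc(-c2cn3ccnc3c(-c3ccc4ncn(C5CCCCC5)c4c3)n2)cc1` gives 31.5%. Among the measured compounds shown here, the one step between them, a number 3.7 percentage points higher from compound 1 to compound 2 (within the scatter), is within the scatter, so compound 2 stands highest of the two numbers only nominally. Compound 3 `c1cn2cc(-c3ccsc3)nc(-c3ccc4ncn(C5CCCCC5)c4c3)c2n1` carries the change (thiophen-3-yl in place of 4-formylphenyl on an aromatic carbon). For the measured compounds named here, no measured step bears on swapping the whole aryl group, and the sole step seen was within the scatter, so he expects no change beyond the scatter in this assay, a step of a number 3.5 percentage points lower from compound 2 to compound 3 (within the scatter). Compound 3 is therefore estimated at 28%, between 10% and 46%.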

Compound 3, a percentage reported as inhibition, at one concentration (the size of the read-out at that concentration, not a potency): 6.29%
For compound 3 the middle estimate is 21.7 percentage points above the measured one; measured number outside the range, below it.
By their numbers in this assay, from the lowest: compound 3; then compounds 1 and 2 (each within the scatter of the next).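

In this assay this position proves sensitive to the kind of aryl group: thiophen-3-yl in place of 4-formylphenyl brings a number 25.2 percentage points lower from compound 2 to compound 3 (beyond the scatter) and thiophen-3-yl in place of phenyl brings a number 21.5 percentage points lower from compound 1 to compound 3 (beyond the scatter) as the two readings of this change. Among the compounds shown here, the formyl step had stayed within the scatter, so only replacing the whole six-membered ring has moved the number so far. Nothing given here accounts for the drop. The compounds shown leave open whether the smaller ring or the sulfur atom goes with the drop. Also open, on these data alone, is whether a pyridine ring, or an amine or carboxylic acid on the phenyl ring, would shift the number.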